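Imide Nitrogen Substitution in a Sulfonamide Receptor Agonist Series

The compounds below may be only part of what the source reports. "The series", "measured", "known", "first", "only" and "open" are said of these compounds alone.

Measured compounds in a functional assay on HEK293 cells for agonist activity at Glucose-dependent insulinotropic receptor (Homo sapiens), read by cAMP accumulation, with a stated time of 30 min; a higher number here means that more compound is needed for the effect, a lower number that less compound is needed:
- compound 1, `COc1cc2c(c(Oc3cccc(NS(=O)(=O)c4ccc(Cl)cc4)c3)n1)C(=O)N(C1CC1)C2=O`: 19 nM
- compound 2, `Cc1cc2c(c(Oc3cccc(NS(=O)(=O)c4ccc(Cl)cc4)c3)n1)C(=O)NC2=O`: 121 nM

Two compounds share a core that carries a sulfonamide-bearing aryl ether. Compound 1 gives 19 nM in this assay. Compound 2 gives 121 nM in this assay, the higher of the two numbers, and the gap between compound 1 and compound 2 lies beyond the usual scatter. Among the measured compounds shown here, compound 1 and compound 2 differ in more than one place, so no single step is drawn between them. The two values only show that compound 2 needs more compound than compound 1.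

Compound 3, `Cc1cc2c(c(Oc3cccc(NS(=O)(=O)c4ccc(Cl)cc4)c3)n1)C(=O)N(C(C)C)C2=O`, is not yet measured. Compared with compound 2 the difference is isopropyl in place of hydrogen on an amide-type nitrogen in a ring.

For the measured compounds named here, the account notes that compound 1, the only compound with a substituent on that amide-type nitrogen, gives 19 nM, and on that basis a step toward a lower number is expected for compound 3, of modest-to-moderate size, a 3.0-fold lower number from compound 2 to compound 3 (0.48 log units; beyond the scatter). Compound 3 is estimated at 40 nM, with a range from 12 nM to 130 nM.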

Compound 3, half-maximal effective concentration: 13 nM
The estimate for compound 3 lay 3.1-fold (0.49 log units) above the measured number, and the stated range covers the measured number.
By their numbers in this assay, from the lowest: compounds 3 and 1 (each within the scatter of the next); then compound 2.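

In this assay, isopropyl in place of hydrogen on an amide-type nitrogen in a ring gives a 9.3-fold lower number from compound 2 to compound 3 (0.97 log units; beyond the scatter), a step beyond the scatter and the only one here that isolates a change at this position. The gap between compound 1 and compound 2 could not be assigned to any one difference, whereas this pair shows that substitution on this nitrogen alone can lower the number, and that the amide hydrogen is not needed for a low number in this assay. Nothing presented here explains the reason for this step.

The compounds leave open how the number would respond to other groups on this nitrogen, such as a methyl group, a longer chain, or a chain ending in an amine or a carboxylic acid. Compound 1 and compound 3 differ in more than one place, so the separate contributions of the cyclopropyl and isopropyl groups, and of the methoxy and methyl groups on the shared core, cannot be read from them.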